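Acid and fluoro variants of the furan-substituted core

The compounds below may be only part of what the source reports. "The series", "measured", "known", "first", "only" and "open" are said of these compounds alone.

Measured so far in an assay on CHO cells for displacement of a labelled ligand from adenosine receptor A1 (Homo sapiens); on this read-out lower numbers stand for stronger inhibition and higher numbers for weaker inhibition:
compound 1, `CCOC(=O)c1cnc(NCc2ccc(F)cc2)n2nc(-c3ccco3)nc12`: 932 nM
compound 2, `COc1ccc(CNc2ncc(C(=O)O)c3nc(-c4ccco4)nn23)cc1`: 5760 nM

Compound 2 gives the higher of the two numbers; the gap to compound 1 lies beyond the scatter. Compound 3, `O=C(O)c1cnc(NCc2ccc(F)cc2)n2nc(-c3ccco3)nc12`, keeps the acid of compound 2 and carries the change (fluoro in place of methoxy on an aromatic carbon), so it shares its benzyl part with compound 1. For the measured compounds named here, no measured pair isolates this change, so the expectation rests on compound 1 giving 932 nM with the same fluorobenzyl group. A modest lowering is expected, a 1.9-fold lower number from compound 2 to compound 3 (0.28 log units; within the scatter). Compound 3 is estimated at 3000 nM, within 900 nM to 10000 nM.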

Compound 3, inhibition constant: > 100000 nM
Compound 3 was reported as a limit (the forecaster's own chance of this, stated with the estimate: 5%); middle value at least 33-fold (1.52 log units) away from the limit.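

In this assay compound 3 gives > 100000 nM, which is a limit of the assay and not a number. With the 4-fluorobenzyl group held, hydrogen in place of ethyl on the oxygen gives an at least 100-fold higher number from compound 1 to compound 3 (2.03 log units; beyond the scatter), and with the acid held, fluoro in place of methoxy gives an at least 17-fold higher number from compound 2 to compound 3 (1.23 log units; beyond the scatter). The acid alone therefore does not settle the read-out, since compound 2 carries it and gives 5760 nM, while the group on the aromatic carbon matters strongly in the acid series.

From the compounds shown here alone, whether hydrogen in place of ethyl costs as much with the 4-methoxybenzyl group stays open. Also open, going by these compounds, is how an amide or a methyl ester would read in place of the acid.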